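The source may report more compounds than this note shows. Statements on the series, on what has been measured and on what is new or still open speak of the compounds shown alone.

Three compounds from one series share a common core and differ only in the aryl group on an amide-type nitrogen. Compound 1 `COc1ccc2nc(C)cc(OCC(=O)Nc3ccc4c(c3)CCC4)c2c1` gives 16.9 mL/min/kg in an ADME assay on liver (Homo sapiens) for metabolic stability, read by LC-MS, using S9 fraction, tested at 2 uM; on this read-out higher numbers stand for fast clearance and lower numbers for slow clearance. Compound 2 `COc1ccc2nc(C)cc(OCC(=O)Nc3ccc(C)c(C)c3)c2c1` gives 16.2 mL/min/kg in this assay, and compound 3 `COc1ccc2nc(C)cc(OCC(=O)Nc3ccc4c(c3)CCCC4)c2c1` gives 15.6 mL/min/kg. Compound 1 holds the highest of the three numbers, yet its gap to compound 2 and to compound 3 lies within the scatter, so the three cannot be ordered. Going by the values given here, the one single-site step measured so far, a 1.0-fold lower number from compound 1 to compound 2 (0.02 log units; within the scatter), shows that exchanging the bicyclic group for a dimethylated phenyl left the clearance essentially unchanged.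

Compound 4 `CCc1ccc(NC(=O)COc2cc(C)nc3ccc(OC)cc23)cc1` has not yet been measured in this assay. Relative to compound 1 it carries 4-ethylphenyl in place of 2,3-dihydro-1H-inden-5-yl on an amide-type nitrogen. The step from compound 1 to compound 2 is the one that bears on this change, and it was flat, so no step beyond the scatter is expected in this assay; the estimated step is a 1.0-fold lower number from compound 1 to compound 4 (0.01 log units; within the scatter). Compound 4 is therefore estimated at 16.5 mL/min/kg, with a range from 10 mL/min/kg to 28 mL/min/kg.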

Compound 4, clearance in the liver assay: 16.6 mL/min/kg
Beside the measured number, compound 4's estimate is 1.0-fold (0.00 log units) below it; measured number inside the range.
By their numbers in the liver assay, from the lowest: compounds 3, 2, 4 and 1 (each within the scatter of the next).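

In the liver assay the step is a 1.0-fold lower number from compound 1 to compound 4 (0.01 log units; within the scatter) and, for 4-ethylphenyl in place of 3,4-dimethylphenyl, a 1.0-fold higher number from compound 2 to compound 4 (0.01 log units; within the scatter) so this place on the amide-type nitrogen now shows a flat read-out also for an aryl group without the five-membered non-aromatic ring. In a physicochemical assay for solubility, in phosphate buffer, measured as kinetic solubility, at pH 7.4 (on this read-out lower numbers stand for lower solubility and higher numbers for higher solubility), compound 1 gives 2800 nM and compound 4 gives 3800 nM and the same exchange, a 1.4-fold higher number from compound 1 to compound 4 (0.13 log units; within the scatter) likewise cannot be read as a difference. No supporting measurement bears on why the numbers stay level.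

Every group shown at this place is built of carbon only. From the compounds shown here alone, whether an aryl group carrying an amine or a carboxylic acid would move the number in the liver assay remains open, as does the effect of any change on the shared core.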